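The source may hold more compounds than are shown below. What is called first, only, known or untested is meant among the compounds shown, and "the series" means these compounds.

Measured compounds:
compound 1 `Cc1cc(C)cc(Cn2cc(Nc3ccccc3)c(=O)[nH]c2=O)c1`: > 200000 nM
compound 2 `O=c1[nH]c(=O)n(Cc2cccc(Cl)c2)cc1Nc1ccccc1`: "not determined" (no result reported)

In an ADME assay on CEM-SS cells (Homo sapiens) for cytotoxicity, read by XTT assay (on this read-out higher numbers stand for lower toxicity in this test and lower numbers for higher toxicity in this test), compound 1 gives > 200000 nM, which is a limit of the assay and not a number. Compound 2 carries "not determined" (no result reported) in this assay. Compound 1 therefore stands only at the limit of > 200000 nM in this assay, at which 1 of the 2 values shown sits, with no single number anywhere to set it against. Compound 3 `Cc1cc(C)cc(Cn2cc(NCc3ccccc3)c(=O)[nH]c2=O)c1` is the untested member of the set, and it differs from compound 1 by benzyl in place of phenyl on a nitrogen on an aromatic ring. Going by the values given here, since compound 1 sits at a limit, no measured step shows how such a change affects this assay, and the expectation is that compound 3 remains within the scatter of compound 1 in this assay, so that the step of a number no higher from compound 1 to compound 3 (the limit leaves the size open) is estimated to be none beyond the scatter. Compound 3 is expected to give 200000 nM in this assay, within 50000 nM to 300000 nM.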

Compound 3, half-maximal cytotoxic concentration: 168000 nM
The estimate for compound 3 lay 1.2-fold (0.08 log units) above the measured number; the measured number falls inside the stated range.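

In this assay, going by these compounds alone, compound 3 gives 168000 nM, the first single number in the set and the first sign that this series can be read at a finite concentration. Compound 1 remains a limit of the assay and not a number: the limit of > 200000 nM in this assay, at which 1 of the 3 values shown sits. Replacing anilino with benzylamino at this nitrogen on an aromatic ring is therefore readable only as an at least 1.1-fold lower number from compound 1 to compound 3 (0.07 log units; that floor lies within the scatter), so the change is not shown to do anything beyond the scatter, though a larger step is not excluded.

The compounds shown leave open how a phenethyl group on this nitrogen would read in this assay, and whether an amine or a carboxylic acid on the benzyl group would shift the number of compound 3 from 168000 nM. From the compounds shown here alone, the true size of the step also stays open, with one end of it resting on a limit.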